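This account rests on a few compounds, and the source may have more. Where it says the series, first, only, none or still open, it means among the compounds named here.

The measured compounds:

Compound 1, `CC(C)N(Cc1cccc(OCCCCCC(=O)O)c1)C(=O)c1ccc(-c2ccc(Cl)c(Cl)c2)cc1`, gives > 26000 nM in an ADME assay on Raji cells (Homo sapiens) for cytotoxicity, read by CellTiter-Glo and resazurin assay, with a stated time of 72 h (a lower number here means that less compound is needed, a higher number that more compound is needed for the effect), a value that is a limit of the assay.
Compound 2, `CCOC(=O)CCCCCOc1cccc(CN(C(=O)c2ccc(-c3cccc(OC(F)(F)F)c3)cc2)C(C)C)c1`, gives > 26000 nM in this assay, again a limit of the assay.
Compound 3, `CCOC(=O)CCCCCOc1ccc(CNC(C)C)cc1`, gives > 26000 nM in this assay, likewise a limit of the assay.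

Compound 3 therefore stands where every measured compound stands: at the limit of > 26000 nM in this assay, at which 3 of the 3 values shown sit. Within the data shown here, no number has been reached for any of them, and there is no measured step between any two of them, so the three values together show only that none of the compounds acted within the range the assay covers.

The compound that follows is compound 4, `CCOC(=O)CCCCCOc1ccc(C(O)O)cc1`. It differs from compound 3 in one place: dihydroxymethyl in place of (isopropylamino)methyl on an aromatic carbon. In words, dihydroxymethyl takes the place of (isopropylamino)methyl on an aromatic carbon.

Among the measured compounds shown here, with no measured step to lean on, the expectation rests on the three limits alone. Since compound 3 sits at the limit, the step from compound 3 to compound 4 is expected to be none beyond the scatter, as a step that the limit leaves unreadable from compound 3 to compound 4. Compound 4 is accordingly expected to give about 30000 nM in this assay, between 12000 nM and 120000 nM, most likely reported again as a limit.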

Compound 4, half-maximal effective concentration: > 27100 nM
Compound 4 ended at the assay's limit; the forecaster's own chance of this, stated with the estimate: 85%; the middle value is on the limit's open side.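

In this assay compound 3 gives > 26000 nM, a limit of the assay. Compound 4 gives > 27100 nM, also a limit, so no step can be read between compound 3 and compound 4. The compounds shown leave open whether dihydroxymethyl in place of (isopropylamino)methyl on an aromatic carbon changes the concentration needed for any effect.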